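The source may report more compounds than this note shows. Statements on the series, on what has been measured and on what is new or still open speak of the compounds shown alone.

Working notes on the series. Compound 1 `COc1ccc(-c2nc(SCC(=O)c3sc(-c4ccccc4)nc3C)[nH]c(=O)c2C#N)cc1` gives 52.1% in a functional assay on U-87MG ATCC cells for antiproliferative activity against U-87 MG (Homo sapiens), read by MTT assay, with a stated time of 48 h, tested at 50 uM (on this read-out lower numbers stand for a stronger effect and higher numbers for a weaker effect at the one concentration tested), the highest of the three numbers: compound 3 `COc1ccc(-c2nc(SCC(=O)c3sc(-c4ccc(Cl)cc4)nc3C)[nH]c(=O)c2C#N)cc1` gives 46.3%, and compound 2 `COc1ccc(-c2nc(C)c(C(=O)CSc3nc(-c4ccc(OC)cc4)c(C#N)c(=O)[nH]3)s2)cc1` gives 32.6%. Compound 4 `Cc1nc(-c2ccccc2)sc1C(=O)CSc1nc(-c2ccccc2)c(C#N)c(=O)[nH]1` differs from compound 1 by hydrogen in place of methoxy on an aromatic carbon. Among the compounds with values here, no measured step touches that ring; the known steps alter the other aryl group: a number 19.5 percentage points lower from compound 1 to compound 2 (beyond the scatter) and a number 5.8 percentage points lower from compound 1 to compound 3 (within the scatter), with a number 13.7 percentage points higher from compound 2 to compound 3 (beyond the scatter) between them. Only the methoxy step was beyond the scatter, and here a methoxy leaves rather than enters, so a step no larger than the scatter is expected, if anything toward a higher number. Compound 4 is therefore estimated at 56% (range 40% to 72%), a step of a number 3.9 percentage points higher from compound 1 to compound 4 (within the scatter) expected.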

Compound 4, a percentage reported as activity, at one concentration (the size of the read-out at that concentration, not a potency): 77.5%
Compound 4: middle estimate off by 21.5 percentage points, on the low side, outside the stated range (above it).
By their numbers in this assay, from the lowest: compound 2; then compounds 3 and 1 (each within the scatter of the next); then compound 4.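

Within the data shown here, removing the methoxy para to a large group gives a number 25.4 percentage points higher from compound 1 to compound 4 (beyond the scatter) in this assay and shows that this aryl position, untouched by the earlier steps, also affects the read-out. With a number 19.5 percentage points lower from compound 1 to compound 2 (beyond the scatter) on the other aryl group, methoxy goes with the lower number in both pairs, though two pairs define no general pattern. No available evidence bears on the reason for this step.

As far as these compounds go, it remains open whether the effect is specific to methoxy or would also appear with a hydroxyl or an amine at this position. From the compounds shown here alone, how such a replacement would combine with a methoxy on the other aryl group also remains open.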